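The compounds below may be only part of what the source reports. "The series", "measured", "known", "first", "only" and "open" are said of these compounds alone.

Measured in a functional assay on L1210 cells (Mus musculus) for inhibition; a higher number here means a weaker inhibitor, a lower number a stronger inhibitor:
- compound 1 `CC(C)CN(CC(=O)N(CC(C)C)NC(=O)OCc1ccccc1)/N=C/c1cccc(B(O)O)c1`: 21200 nM
- compound 2 `CC(C)CN(CC(=O)N(Cc1ccccc1)NC(=O)OCc1ccccc1)/N=C/c1cccc(B(O)O)c1`: 16900 nM

Compound 2, at 16900 nM, cannot be separated from compound 1, since the two values lie within the scatter of each other. The next analogue is compound 3 `CC(C)CN(CC(=O)N(Cc1cccnc1)NC(=O)OCc1ccccc1)/N=C/c1cccc(B(O)O)c1`, still to be measured in this assay. The change is pyridin-3-yl in place of phenyl on a saturated chain carbon bound to an amide-type nitrogen.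

Going by the values given here, only one measured step bears on this. It altered the same place, replacing isopropyl with phenyl, and gave a 1.3-fold lower number from compound 1 to compound 2 (0.10 log units; within the scatter). Among the compounds with values here, no compound carrying pyridin-3-yl has been measured, so the direction remains open and no shift beyond the scatter is anticipated.

The expected step is a 1.1-fold higher number from compound 2 to compound 3 (0.05 log units; within the scatter).

For compound 3 the estimated value is 19000 nM, with an expected range of 8000 nM to 45000 nM.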

Compound 3, half-maximal inhibitory concentration: 41600 nM
The estimate for compound 3 lay 2.2-fold (0.34 log units) below the measured number, within the range that was stated.
By their numbers in this assay, from the lowest: compounds 2, 1 and 3 (each within the scatter of the next, the first and the last beyond it).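

In this assay, going by these compounds alone, the exchange of phenyl for pyridin-3-yl gives a 2.5-fold higher number from compound 2 to compound 3 (0.39 log units; beyond the scatter) and is the first step at this place, on a saturated chain carbon bound to an amide-type nitrogen, to pass beyond the scatter. The heavy-atom count stays the same and the entering ring adds one hydrogen-bond acceptor, so this place responds to a change within the aromatic ring alone, whereas isopropyl and phenyl could not be separated. Within the data shown here, the comparison with isopropyl gives a 2.0-fold higher number from compound 1 to compound 3 (0.29 log units; within the scatter) and does not separate compound 1 from compound 3, so only the pair of compound 2 and compound 3 is resolved.

Still open, on these data alone, is how pyridin-4-yl, a primary amine or a carboxylic acid would read at this place. Nothing available here explains the step from phenyl to pyridin-3-yl.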